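A few compounds are considered here, and "the series" means these few. Any claim that something is new, unique, unknown or untested is made for them only; others in the source may bear on it.

In a functional assay on MCF7 cells (Homo sapiens) for cytotoxicity, read by fluorescence, with a stated time of 72 h (on this read-out higher numbers stand for weaker inhibition and lower numbers for stronger inhibition), compound 1 (`CSc1nc(NCc2ccc(-c3ccccn3)cc2)c2[nH]nc(C(C)C)c2n1`) gives 819 nM and compound 2 (`CC(C)c1n[nH]c2c(NCc3ccc(-c4ccccn4)cc3)nc(NCC(N)CO)nc12`) gives 310 nM as the lower of the two numbers. Going by the values given here, the one measured step (a 2.6-fold lower number from compound 1 to compound 2 (0.42 log units; beyond the scatter)) is modest but beyond the scatter.

Compound 3 (`CC(C)c1n[nH]c2c(NCc3ccc(-c4ccccn4)cc3)nc(NCCN(C)C)nc12`) has no number yet. It differs from compound 2 only in the chain ((dimethylamino)methyl in place of 1-amino-2-hydroxyethyl on a saturated chain carbon bound to a nitrogen on an aromatic ring), a change that, cut one bond further out, reads 2-amino-3-hydroxypropyl to 2-(dimethylamino)ethyl.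

Among the compounds with values here, no measured step alters this chain itself. Within the data shown here, the one available step replaced the whole group on the aromatic carbon, so it bears only loosely on this change. Its modest size (a 2.6-fold lower number from compound 1 to compound 2 (0.42 log units; beyond the scatter)) still sets the only scale in the series. A smaller shift is expected here in this assay and nothing beyond the scatter, with a slightly higher number as the likelier direction. The expected step is a 1.3-fold higher number from compound 2 to compound 3 (0.11 log units; within the scatter) as a rough estimate. For compound 3 the estimated value is 400 nM with an expected range from 150 nM to 1000 nM in this series.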

Compound 3, half-maximal inhibitory concentration: 225 nM
The estimate for compound 3 lay 1.8-fold (0.25 log units) above the measured number; measured number inside the range.
By their numbers in this assay, from the lowest: compounds 3 and 2 (each within the scatter of the next); then compound 1.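

In this assay, 2-(dimethylamino)ethyl in place of 2-amino-3-hydroxypropyl gives a 1.4-fold lower number from compound 2 to compound 3 (0.14 log units; within the scatter), so these two chains are not told apart here, even though the hydrogen-bond donors counted on the leaving group are absent from the entering one. Both chains, each compared with methylsulfanyl on the aromatic carbon, give a modest step beyond the scatter: a 2.6-fold lower number from compound 1 to compound 2 (0.42 log units; beyond the scatter) and a 3.6-fold lower number from compound 1 to compound 3 (0.56 log units; beyond the scatter); in these three compounds, the amino-bearing chains share that direction, and no compound shown goes against it. No supporting data accompany these numbers that could account for either step.

Going by these compounds, whether a longer chain, a piperazine ring or a chain ending in a carboxylic acid in place of 2-(dimethylamino)ethyl would stand apart from these two chains in this assay remains open. Also open, on these data alone, is whether a plain alkyl chain with no amine would keep the step seen from methylsulfanyl, which would show how far that step depends on the amine itself.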